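The compounds below may be only part of what the source reports. "The series", "measured", "known", "first", "only" and "open" are said of these compounds alone.

Compounds measured:
compound 1, `FC(F)(F)c1ccc(CSc2nc(Nc3cccc(Cl)c3)c3ccccc3n2)cc1`: 18000 nM
compound 2, `O=[N+]([O-])c1cccc(Nc2nc(SCc3ccc(C(F)(F)F)cc3)nc3ccccc23)c1`: 31500 nM

Both compounds were tested in a functional assay on MDA-MB-231 cells (Homo sapiens) for cytotoxicity, read by MTT assay, with a stated time of 72 h (a higher number here means a weaker inhibitor, a lower number a stronger inhibitor), a cytotoxicity measurement read after the stated time. Compound 1 gives 18000 nM there, and compound 2 gives 31500 nM. For the measured compounds named here, the single step between them, a 1.8-fold higher number from compound 1 to compound 2 (0.24 log units; within the scatter), is within the scatter, so the two numbers cannot be told apart; compound 2 holds the highest of the two numbers, with compound 1 nearest.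

Compound 3, `COc1cc(Nc2nc(SCc3ccc(C(F)(F)F)cc3)nc3ccccc23)cc(OC)c1`, is not yet measured. It differs from compound 2 in one place: 3,5-dimethoxyphenyl in place of 3-nitrophenyl on a nitrogen on an aromatic ring

Going by the values given here, no measured step bears directly on this change. Among the compounds with values here, the only step in hand, a 1.8-fold higher number from compound 1 to compound 2 (0.24 log units; within the scatter), tells that exchanging one group on that nitrogen for another left the number within the scatter, but the group entering compound 3 is different from either of those. The expectation therefore rests mainly on compound 2 itself, with a wide range around it. On that basis, compound 3 is expected to sit near compound 2 in this assay, with a step of a 1.3-fold lower number from compound 2 to compound 3 (0.10 log units; within the scatter). The estimate for compound 3 is 25000 nM, between 8000 nM and 80000 nM.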

Compound 3, half-maximal inhibitory concentration: 16100 nM
For compound 3 the middle estimate is 1.6-fold (0.19 log units) above the measured one; the measured number falls inside the stated range.
By their numbers in this assay, from the lowest: compounds 3, 1 and 2 (each within the scatter of the next).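

In this assay, the 3,5-dimethoxyphenyl group on the nitrogen gives a step of a 2.0-fold lower number from compound 2 to compound 3 (0.29 log units; within the scatter) against 3-nitrophenyl and a step of a 1.1-fold lower number from compound 1 to compound 3 (0.05 log units; within the scatter) against 3-chlorophenyl, and neither step separates the compounds. The earlier pair compared only phenyl rings with one substituent each, whereas this group carries two methoxy groups and has 10 heavy atoms, yet compounds 1, 2 and 3 all remain within the scatter of one another, so no difference among these three aryl groups can be read at this place. Nothing at hand gives a reason for this result.

The three compounds leave open whether any group on this nitrogen can move the number beyond the scatter, since all three groups shown are substituted phenyl rings. A phenyl ring bearing a carboxylic acid or a primary amine, or a cyclohexyl ring or a longer alkyl chain in place of the phenyl ring, could show whether this place tolerates wider change or whether the number depends on it at all.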